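Solubility notes on a five-membered ring swap

The compounds below may be only part of what the source reports. "The series", "measured", "known", "first", "only" and "open" are said of these compounds alone.

Measured in a physicochemical assay for solubility, read by LC-MS, in phosphate buffer, with a stated time of 24 h, at pH 7.4; a higher number here means a more soluble compound, a lower number a less soluble compound:
compound 1 `Cn1cc(-c2cnc(NCc3c(F)ccc4c3CCO4)c3cn[nH]c(=O)c23)cn1` gives 1000 nM
compound 2 `Cc1nccn1-c1cnc(NCc2c(F)ccc3c2CCO3)c2cn[nH]c(=O)c12` gives 7000 nM

Compound 2 (7000 nM) stands highest of the two numbers. Compound 3 (`Cn1nccc1-c1cnc(NCc2c(F)ccc3c2CCO3)c2cn[nH]c(=O)c12`) remains unmeasured and carries 1-methyl-1H-pyrazol-5-yl in place of 2-methyl-1H-imidazol-1-yl on an aromatic carbon. Going by the values given here, only one measured step bears on this, and only indirectly: 2-methyl-1H-imidazol-1-yl replacing 1-methyl-1H-pyrazol-4-yl gave a modest change beyond the scatter (a 7.0-fold higher number from compound 1 to compound 2 (0.85 log units; beyond the scatter)). With a pyrazolyl group restored, a partial return in this assay toward lower numbers is expected (a 2.3-fold lower number from compound 2 to compound 3 (0.37 log units; beyond the scatter)). Compound 3 is estimated at (3000 nM, range 800 nM to 10000 nM).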

Compound 3, solubility: 2000 nM
For compound 3 the middle estimate is 1.5-fold (0.18 log units) above the measured one; measured number inside the range.
By their numbers in this assay, from the lowest: compounds 1 and 3 (each within the scatter of the next); then compound 2.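

In this assay the two pyrazolyl isomers cannot be told apart: 1-methyl-1H-pyrazol-5-yl in place of 1-methyl-1H-pyrazol-4-yl gives a 2.0-fold higher number from compound 1 to compound 3 (0.30 log units; within the scatter). 2-methyl-1H-imidazol-1-yl stands apart from both, and even with the same atoms and the same counts, its replacement by 1-methyl-1H-pyrazol-5-yl gives a 3.5-fold lower number from compound 2 to compound 3 (0.54 log units; beyond the scatter). Nothing measured accounts for this difference.

Still open, as far as these compounds go, is whether the higher number of compound 2 follows the imidazole ring or its methyl group. Also open, from the compounds shown here alone, is how an unsubstituted 1H-imidazol-1-yl or a dimethylamino group on this aromatic carbon would read in this assay.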